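Propyl to isopropyl on the amide chain of compound 3

This account rests on a few compounds, and the source may have more. Where it says the series, first, only, none or still open, it means among the compounds named here.

Measured so far in a functional assay on A549 cells (Homo sapiens) for antiproliferative activity, read by CCK-8 assay, with a stated time of 72 h; a higher number here means a weaker inhibitor of growth, a lower number a stronger inhibitor of growth:
compound 1, `CCC1C(=O)N(C)c2cnc(Nc3ccc(S(=O)(=O)NCC(C)C)cc3)nc2N1c1ccn(C)n1`, gives 31600 nM
compound 2, `CCCCNS(=O)(=O)c1ccc(Nc2ncc3c(n2)N(c2ccn(C)n2)C(CC)C(=O)N3C)cc1`, gives 10600 nM
compound 3, `CCCCNC(=O)c1ccc2c(ccn2-c2ncc3c(n2)N(C2CCCC2)[C@H](CC)C(=O)N3C)c1`, gives 1160 nM

Compound 3 stands lowest of the three in this assay, its steps to compound 2 and to compound 1 both beyond the scatter. The difference between the core of compound 3 and the core of compound 2 is not broken down here.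

One change is already measured within the series: from compound 2 to compound 1, (isopropyl in place of propyl on a saturated chain carbon bound to a sulfonamide nitrogen), the number moves by a 3.0-fold higher number from compound 2 to compound 1 (0.47 log units; beyond the scatter), a modest loss of growth inhibition.

Compound 4, `CC[C@@H]1C(=O)N(C)c2cnc(-n3ccc4cc(C(=O)NCC(C)C)ccc43)nc2N1C1CCCC1`, is not yet measured. It differs from compound 3 by isopropyl in place of propyl on a saturated chain carbon bound to an amide-type nitrogen. Within the data shown here, this is the same kind of change as the one from compound 2 to compound 1, but not the same: there the place was a saturated chain carbon bound to a sulfonamide nitrogen, here it is a saturated chain carbon bound to an amide-type nitrogen, and the surrounding core is that of compound 3, whose difference from compound 2 is not broken down.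

The expectation for compound 4 rests on a single measured step of this kind and is therefore loose. Compound 4 is expected to show a 2.8-fold higher number from compound 3 to compound 4 (0.44 log units; beyond the scatter) in this assay, a step of about the size seen from compound 2 to compound 1 because that pair gave a 3.0-fold higher number from compound 2 to compound 1 (0.47 log units; beyond the scatter). Compound 4 is estimated at 3200 nM, with a likely range from 1100 nM to 9500 nM.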

Compound 4, concentration for 50% growth inhibition: 1730 nM
Compound 4: the middle estimate sits 1.8-fold (0.27 log units) above what was measured, and the stated range covers the measured number.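

In this assay, isopropyl in place of propyl on a saturated chain carbon bound to an amide-type nitrogen gives a 1.5-fold higher number from compound 3 to compound 4 (0.17 log units; within the scatter), so the two amides cannot be told apart in this read-out. Set beside the sulfonamide pair, the two steps do not differ by more than the scatter of two such steps allows: the same change on two cores in this assay, a 3.0-fold higher number (0.47 log units; beyond the scatter) from compound 2 to compound 1 and a 1.5-fold higher number (0.17 log units; within the scatter) from compound 3 to compound 4, 2.0-fold (0.30 log units) apart, within the scatter of two such steps. The change thus carries from one core to the other without a measurable difference in step size, although only the sulfonamide step lies beyond the scatter; two pairs do not show that the step is truly the same on both cores, and with the core and the chain attachment differing together, neither can be credited with any part of the gap between the steps.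

The compounds shown leave open how the amide chain of compound 3 responds to larger changes than this rearrangement of the same carbon atoms, such as a longer chain, a cyclopropylmethyl group or a chain ending in an amine or a carboxylic acid. Also open, on these data alone, is whether the isopropyl-for-propyl step stays this size on a third core.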